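The compounds below may be only part of what the source reports. "The series", "measured", "known", "first", "only" and "open" are said of these compounds alone.

The measured compounds and their values in a toxicity assay on NIH3T3 cells (Mus musculus) for cytotoxicity, read by resazurin assay; on this read-out lower numbers stand for an effect already at smaller amounts and higher numbers for an effect only at larger amounts of compound:

Compound 1, `COC(=O)c1ccc(NCc2cncn2Cc2cccc(F)c2)cc1-c1ccccc1`: > 1000 nM.
Compound 2, `CCOC(=O)c1ccc(NCc2cncn2Cc2ccc(-c3ccccc3)cc2)cc1-c1ccccc1`: > 10000 nM.
Compound 3, `c1ccc(-c2ccc(Cn3cncc3CNc3ccc(-c4ccc[nH]4)c(-c4ccccc4)c3)cc2)cc1`: > 10000 nM.

In this assay compound 1 stands at > 1000 nM, which is a limit of the assay and not a number. For compound 2 the result is likewise a limit, > 10000 nM. Compound 3 also reaches only a limit, > 10000 nM. Among the measured compounds shown here, the sole step between measured compounds, a step that the two limits leave unreadable from compound 2 to compound 3, concerns a different part of the molecule than the change followed here, and its size cannot be read. Compound 4, `COC(=O)c1ccc(NCc2cncn2Cc2ccc(C#N)cc2)cc1-c1ccccc1`, differs from compound 1 by 4-cyanophenyl in place of 3-fluorophenyl on a saturated chain carbon bound to an aromatic nitrogen. For the measured compounds named here, no measured step touches this part of the molecule, so neither a size nor a direction can be taken from the data. The evidence consists of limits alone: the limit of > 1000 nM in this assay, at which 1 of the 3 values shown sits, and (the limit of > 10000 nM in this assay, at which 2 of the 3 values shown sit). Because compound 1 gave > 1000 nM, compound 4 is expected to return a limit again in this assay rather than a number. The estimate for compound 4 is 10000 nM, with an expected range from 1000 nM to 100000 nM. This amounts to an expected step that the limit leaves unreadable from compound 1 to compound 4.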

Compound 4, half-maximal effective concentration: > 10000 nM
Compound 4: no number, only a limit (the forecaster's own chance of this, stated with the estimate: 85%); the middle value lies on the limit itself.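

In this assay compound 1 and compound 4 both give only limits of the assay and not numbers, so no step can be read between them. The compounds shown leave open at what concentration any of them would produce a half-maximal effect: all four results are limits.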